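This account rests on a few compounds, and the source may have more. Where it says the series, first, only, none or still open, it means among the compounds named here.

Compound 1, `CCOC(=O)c1cnc(C(F)(F)F)nc1NN1C(=O)C=C(C)C1=O`, is measured in a functional assay on Jurkat cells for inhibition of nuclear factor NF-kappa-B complex (Homo sapiens) (a lower number here means a stronger inhibitor, a higher number a weaker inhibitor), at 1000 nM, the second highest of the three numbers recorded. Compound 2, `CCOC(=O)c1cnc(-c2cccs2)nc1NN1C(=O)C=C(C)C1=O`, gives 20 nM, and compound 3, `CCOC(=O)c1cnc(-c2cccc(OC)c2)nc1NN1C(=O)C=C(C)C1=O`, gives 5000 nM; the step of a 50-fold lower number from compound 1 to compound 2 (1.70 log units; beyond the scatter) is large, while the step of a 5.0-fold higher number from compound 1 to compound 3 (0.70 log units; beyond the scatter) runs the other way and is modest, and between them a 250-fold higher number from compound 2 to compound 3 (2.40 log units; beyond the scatter) is the largest gap in the set. Compound 4, `CCOC(=O)c1cnc(-c2ccc(C)s2)nc1NN1C(=O)C=C(C)C1=O`, differs from compound 1 in one place: 5-methylthiophen-2-yl in place of trifluoromethyl on an aromatic carbon. The closest precedent is the step to compound 2, which put a thiophen-2-yl in the same place and gave the large gain shown by a 50-fold lower number from compound 1 to compound 2 (1.70 log units; beyond the scatter); compound 4 carries 5-methylthiophen-2-yl, so that step is the most relevant one, with the methyl an untested addition. Compound 3 shows that not every aromatic group in that place helps, so some caution remains. Compound 4 is therefore expected to come out near compound 2, with a step of a 33-fold lower number from compound 1 to compound 4 (1.52 log units; beyond the scatter), and its estimated value is 30 nM, within a range from 8 nM to 150 nM.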

Compound 4, half-maximal inhibitory concentration: 200 nM
For compound 4 the middle estimate is 6.7-fold (0.82 log units) below the measured one; measured number above the stated range.
By their numbers in this assay, from the lowest: compound 2; then compound 4; then compound 1; then compound 3.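

Adding a methyl to the thiophene is the first change here that keeps the ring in place, and it gives a 10-fold higher number from compound 2 to compound 4 (1.00 log units; beyond the scatter) in this assay, so this position responds to more than the type of ring attached. The 5-methylthiophen-2-yl group still improves on the earlier groups, with a 5.0-fold lower number from compound 1 to compound 4 (0.70 log units; beyond the scatter) and a 25-fold lower number from compound 3 to compound 4 (1.40 log units; beyond the scatter), which means that only part of the gain seen with thiophen-2-yl survives the added methyl. No evidence is available to explain these differences.

The compounds shown leave open whether a chlorine or an ethyl in place of that methyl would give a similar loss. They also leave open how a furan-2-yl group or an amine in place of trifluoromethyl would compare.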